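The compounds below may be only part of what the source reports. "The series", "measured", "known", "first", "only" and "open" are said of these compounds alone.

The series shares one core and varies the aryl group attached to the sulfonyl sulfur. Compound 1 `COc1cc2nc(N3CCN(S(=O)(=O)c4ccc(Br)cc4)CC3)nc(N)c2cc1OC` gives 20000 nM in a functional assay on PC-3 cells (Homo sapiens) for inhibition; a higher number here means a weaker inhibitor, a lower number a stronger inhibitor. Compound 2 `COc1ccc(S(=O)(=O)N2CCN(c3nc(N)c4cc(OC)c(OC)cc4n3)CC2)cc1` gives 39000 nM in this assay, and compound 3 `COc1cc2nc(N3CCN(S(=O)(=O)c4ccc(OC(F)(F)F)cc4)CC3)nc(N)c2cc1OC` gives 25000 nM in this assay. Among the three numbers, compound 3 stands second highest, with compound 1 nearest and compound 2 furthest, both within the scatter. Among the compounds with values here, the three steps so far, a 2.0-fold higher number from compound 1 to compound 2 (0.29 log units; within the scatter), a 1.3-fold higher number from compound 1 to compound 3 (0.10 log units; within the scatter) and a 1.6-fold lower number from compound 2 to compound 3 (0.19 log units; within the scatter), each vary one substituent of the aryl group on the sulfonyl sulfur, and none reaches beyond the scatter.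

Compound 4 `COc1cc2nc(N3CCN(S(=O)(=O)c4ccc5ccccc5c4)CC3)nc(N)c2cc1OC` has not been measured in this assay. It differs from compound 3 in one place: naphthalen-2-yl in place of 4-(trifluoromethoxy)phenyl on a sulfonyl sulfur. Within the data shown here, no measured step exchanges the whole aryl group, so the move from compound 3 to compound 4 has no direct precedent. Among the measured compounds shown here, the steps that bear on it, only loosely, are the three above, all within the scatter, and they give no ground to expect a number for compound 4 beyond the scatter on either side. The expected step is no change at the digits printed from compound 3 to compound 4 (within the scatter). Compound 4 is therefore estimated at 25000 nM in this assay, with a range from 8000 nM to 80000 nM.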

Compound 4, half-maximal inhibitory concentration: 15000 nM
Estimate against measurement, compound 4: 1.7-fold (0.22 log units) above; the range from low to high includes it.
By their numbers in this assay, from the lowest: compounds 4, 1, 3 and 2 (each within the scatter of the next, the first and the last beyond it).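

Compared with the single substituted rings of the earlier compounds, naphthalen-2-yl places two six-membered aromatic rings of carbon only on the sulfonyl sulfur, and the numbers do not separate from those of the 4-bromophenyl and 4-(trifluoromethoxy)phenyl compounds: a 1.3-fold lower number from compound 1 to compound 4 (0.12 log units; within the scatter) and a 1.7-fold lower number from compound 3 to compound 4 (0.22 log units; within the scatter). Within the data shown here, the same exchange against 4-methoxyphenyl gives the only step that lies beyond the scatter, a 2.6-fold lower number from compound 2 to compound 4 (0.41 log units; beyond the scatter), although it is modest and compound 4 at 15000 nM remains within the scatter of compounds 1 and 3 in this assay. No measurement at hand accounts for why this one step passes the scatter while the other two do not.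

On these data alone, whether an aryl group carrying an amine or a carboxylic acid, or a cyclohexyl group in place of the aryl group, would move the number beyond the scatter of compound 4 stays open. All four compounds share the same core, so they do not show how a change to the core, such as a longer chain in place of either methoxy group, would read in this assay.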